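The compounds below may be only part of what the source reports. "The series", "measured", "known", "first", "only" and "open" are said of these compounds alone.

Measured so far:
compound 1, `CCCCC(OC)c1cccc(NC(=O)NCCCCl)c1` — in a functional assay on HT-29 cells (Homo sapiens) for antiproliferative activity, with a stated time of 48 h (on this read-out lower numbers stand for stronger inhibition and higher numbers for weaker inhibition), compound 1 gives 56000 nM
compound 2, `CCCCC(O)c1cccc(NC(=O)NC(=O)CC)c1` — in this assay compound 2 gives > 100000 nM

The value for compound 2 is not a number but a limit of the assay, (the limit of > 100000 nM in this assay, at which 1 of the 2 values shown sits). Compound 1 returns a number, but it differs from compound 2 in two places, so the two values show only that both sit high on this read-out. Compound 3, `CCCCC(OC)c1cccc(NC(=O)NC(=O)CC)c1`, is not yet measured; it carries methyl in place of hydrogen on an oxygen on a saturated carbon, that is, methyl in place of hydrogen on an oxygen on a saturated carbon, hydroxy to methoxy, 1-hydroxypentyl to 1-methoxypentyl. Among the compounds with values here, no measured step isolates this change. With compound 2 at a limit, the step in this assay cannot be sized from the data; nothing beyond the scatter is expected, and a further limit is the most probable outcome. Compound 3 is estimated at 90000 nM, range 30000 nM to 300000 nM. That estimate means an expected step of an at least 1.1-fold lower number from compound 2 to compound 3 (0.04 log units; that floor lies within the scatter), a placeholder around the limit rather than a real shift.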

Compound 3, half-maximal inhibitory concentration: > 100000 nM
Compound 3 gave a limit, no number (the forecaster's own chance of this, stated with the estimate: 55%); middle value at least 1.1-fold (0.04 log units) from the limit.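

Methyl in place of hydrogen on an oxygen on a saturated carbon, hydroxy to methoxy, gives no readable step in this assay, since compound 2 and compound 3 both stand at a limit: the limit of > 100000 nM in this assay, at which 2 of the 3 values shown sit.

With propanoyl on the amide-type nitrogen, neither the 1-hydroxypentyl nor the 1-methoxypentyl group yields a number. A single-place comparison now exists for the other end of the molecule: with 1-methoxypentyl held, propanoyl in place of 3-chloropropyl gives an at least 1.7-fold higher number from compound 1 to compound 3 (0.25 log units; that floor lies within the scatter), so this change is not shown to exceed the scatter.

From the compounds shown here alone, the size of the hydroxy to methoxy step stays open until it is read on a background that returns a number, such as one carrying 3-chloropropyl. Also open, going by these compounds, is how a longer chain on that oxygen, or an amine in place of the propanoyl group, would read in this assay.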